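Methoxy in Place of Methyl Across Two Matched Pairs

The source may hold more compounds than are shown below. What is called first, only, known or untested is meant among the compounds shown, and "the series" means these compounds.

Three compounds have been measured in a functional assay on MCF7 cells (Homo sapiens) for inhibition, read by colorimetric assay and MTT assay, with a stated time of 72 h; on this read-out lower numbers stand for stronger inhibition and higher numbers for weaker inhibition:

Compound 1 `Cc1ccc(C(=O)NNC(=S)Nc2csc(-c3ccccc3)c2)cc1` gives 30000 nM.
Compound 2 `COc1ccc(C(=O)NNC(=S)Nc2csc(-c3ccccc3)c2)cc1` gives 32000 nM.
Compound 3 `Cc1ccc(-c2nnc(Nc3csc(-c4ccccc4)c3)s2)cc1` gives 34000 nM.

Compound 1 and compound 2 share the same core and differ in a single place, (methoxy in place of methyl on an aromatic carbon). The step this change made is a 1.1-fold higher number from compound 1 to compound 2 (0.03 log units; within the scatter), so on this read-out the two compounds are indistinguishable.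

Compound 3 carries a different core, and the difference between the two cores is not broken down here. What its value shows is that compound 3 and compound 1 give numbers lying within the scatter of one another, as do compound 3 and compound 2; no order among the three can be stated.

Compound 4 `COc1ccc(-c2nnc(Nc3csc(-c4ccccc4)c3)s2)cc1` has not yet been measured. It is related to compound 3 by methoxy in place of methyl on an aromatic carbon, and the place of this change reads the same, word for word, as in the pair of compound 1 and compound 2, so it is the same change made on the core of compound 3. Because a 1.1-fold higher number from compound 1 to compound 2 (0.03 log units; within the scatter) was within the scatter, the step from compound 3 to compound 4 is expected to be of the same kind and size, a 1.1-fold higher number from compound 3 to compound 4 (0.02 log units; within the scatter). On that basis compound 4 is estimated to give 36000 nM in this assay, with a likely range from 18000 nM to 72000 nM. This expectation rests on one measured pair only.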

Compound 4, half-maximal inhibitory concentration: 60000 nM
Compound 4: middle estimate off by 1.7-fold (0.22 log units), on the low side; the measured number falls inside the stated range.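

In this assay, methoxy in place of methyl on an aromatic carbon gives a 1.8-fold higher number from compound 3 to compound 4 (0.25 log units; within the scatter) and so leaves the two compounds on the core of compound 3 indistinguishable on this read-out, just as the same change left the two compounds on the core of compound 1 indistinguishable. Set side by side, the two steps do not differ by more than repeated measurements of this kind would be expected to, so the change reads the same on both cores as far as these data can tell: the same change on two cores in this assay, a 1.1-fold higher number (0.03 log units; within the scatter) from compound 1 to compound 2 and a 1.8-fold higher number (0.25 log units; within the scatter) from compound 3 to compound 4, 1.7-fold (0.22 log units) apart, within the scatter of two such steps. This agreement does not show that the change has no effect in general or that the two cores respond identically, and two matched pairs, each with a step within the scatter, are too few to establish a rule for the whole series.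

The compounds shown carry only the 4-methylphenyl and 4-methoxyphenyl groups, so it remains open what an amine, a carboxylic acid or a longer chain such as ethoxy would give in that place. From the compounds shown here alone, it also remains open whether the swap of methyl for methoxy would read the same on a third core.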